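A few compounds are considered here, and "the series" means these few. Any claim that something is new, unique, unknown or untested is made for them only; others in the source may bear on it.

Measured so far in an assay on cells for agonist activity at ecdysone receptor (Bombyx mori), read by a luciferase reporter, with a stated time of 24 h; on this read-out lower numbers stand for an effect already at smaller amounts and higher numbers for an effect only at larger amounts of compound:
compound 1 `Cc1cc(C)cc(C(=O)N(NC(=O)c2ccccc2)C(C)(C)C)c1`: 69.2 nM
compound 2 `COc1cccc(C(=O)NN(C(=O)c2ccccc2Cl)C(C)(C)C)c1`: 52.5 nM
compound 3 `Cc1ccc(C)c(C(=O)NN(C(=O)c2ccccc2Cl)C(C)(C)C)c1`: 1620 nM

Among the three numbers compound 2 stands at the low end. Compound 1 lies within the scatter of it, so the two are not separated by this assay. Compound 3 stands furthest from compound 2, and the step of a 31-fold higher number from compound 2 to compound 3 (1.49 log units; beyond the scatter) is large; that step exchanges the group on the other carbonyl carbon, not the part changed here.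

Compound 4 `COc1cccc(C(=O)NN(C(=O)c2cc(C)cc(C)c2)C(C)(C)C)c1` is not yet measured in this assay. It differs from compound 2 by 3,5-dimethylphenyl in place of 2-chlorophenyl on a carbonyl carbon. For the measured compounds named here, no measured pair isolates this exchange. Going by the values given here, the only bearing comes from compound 1, which carries 3,5-dimethylphenyl on the same carbonyl carbon and gives a number close to that of compound 2 in this assay; its group on the other carbonyl differs, so the support is indirect. On that basis no step beyond the scatter is expected from compound 2 to compound 4, a 1.2-fold lower number from compound 2 to compound 4 (0.07 log units; within the scatter). The estimate for compound 4 in this assay is 45 nM, with a range from 12 nM to 170 nM.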

Compound 4, half-maximal effective concentration: 66.1 nM
Compound 4: middle estimate off by 1.5-fold (0.17 log units), on the low side; low and high end bracket the measured number.
By their numbers in this assay, from the lowest: compounds 2, 4 and 1 (each within the scatter of the next); then compound 3.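

In this assay, the exchange of 2-chlorophenyl for 3,5-dimethylphenyl on a carbonyl carbon whose other neighbour is the amide-type nitrogen can now be read directly, with 3-methoxyphenyl held on the other carbonyl: a 1.3-fold higher number from compound 2 to compound 4 (0.10 log units; within the scatter) shows that this position carries either group without a separation in this read-out. The new compound also isolates a second place, where methoxy in place of hydrogen on an aromatic carbon, with 3,5-dimethylphenyl held constant, gives a 1.0-fold lower number from compound 1 to compound 4 (0.02 log units; within the scatter) and so again leaves the pair unseparated. No evidence is available on what lies behind either result.

From the compounds shown here alone, both groups read at this position are six-membered aromatic carbon rings without hydrogen-bond donors or acceptors, so it remains open how the position responds to a ring bearing an amine or a carboxylic acid. Also open, going by these compounds, is whether the large step of a 31-fold higher number from compound 2 to compound 3 (1.49 log units; beyond the scatter), which falls on the other carbonyl carbon, recurs when 3,5-dimethylphenyl stands in place of 2-chlorophenyl.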